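Swapping Chlorine for Hydroxyl on the Hydrazone Aryl Ring

The source may hold more compounds than are shown below. What is called first, only, known or untested is meant among the compounds shown, and "the series" means these compounds.

Of the compounds shown here, three sharing one core have been measured. Compound 1 `COc1ccc(OC)c(/C=N/NC(=O)Nc2ccc(Oc3ccnc(-c4nncn4CCN(C)C)c3)c(F)c2)c1` gives 2930 nM in a functional assay on NCI-H460 cells (Homo sapiens) for cytotoxicity, read by MTT assay, with a stated time of 72 h; a lower number here means a stronger inhibitor, a higher number a weaker inhibitor. Compound 2 `CN(C)CCn1cnnc1-c1cc(Oc2ccc(NC(=O)N/N=C/c3cccc(Br)c3)cc2F)ccn1` gives 520 nM in this assay, and compound 3 `CN(C)CCn1cnnc1-c1cc(Oc2ccc(NC(=O)N/N=C/c3ccc(Cl)cc3)cc2F)ccn1` gives 320 nM in this assay. Compound 3 therefore holds the lowest of the three numbers, though its separation from compound 2, a 1.6-fold lower number from compound 2 to compound 3 (0.21 log units; within the scatter), is within the scatter, so these two cannot be ranked against each other. Against compound 1 the separation is clear: a 9.2-fold lower number from compound 1 to compound 3 (0.96 log units; beyond the scatter) and a 5.6-fold lower number from compound 1 to compound 2 (0.75 log units; beyond the scatter) both lie beyond the scatter.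

Compound 4 `CN(C)CCn1cnnc1-c1cc(Oc2ccc(NC(=O)N/N=C/c3ccc(O)cc3)cc2F)ccn1` differs from compound 3 in a single place: hydroxy in place of chloro on an aromatic carbon. Among the measured compounds shown here, no measured step exchanges a halogen for a hydroxy group, so there is no direct precedent. What the data do show is that the two halogen-bearing rings of compounds 2 and 3 sit well below the dimethoxy ring of compound 1, and that exchanging one halogen for another changed little. Moving to a hydroxy group is untested here, so a modest rise in the number is expected, a 2.8-fold higher number from compound 3 to compound 4 (0.45 log units; beyond the scatter), with wide uncertainty. Compound 4 is estimated at 900 nM, with a range from 300 nM to 3000 nM.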

Compound 4, half-maximal inhibitory concentration: 1780 nM
Beside the measured number, compound 4's estimate is 2.0-fold (0.30 log units) below it, and the stated range covers the measured number.
By their numbers in this assay, from the lowest: compounds 3 and 2 (each within the scatter of the next); then compounds 4 and 1 (each within the scatter of the next).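

Even a change of a single heavy atom on this aromatic carbon, para to a large group, counts in this assay: hydroxy in place of chloro gives a 5.6-fold higher number from compound 3 to compound 4 (0.75 log units; beyond the scatter), the first direct measure of what leaving the halogen costs at this position. The hydroxy ring also stands apart from the other halogen-bearing ring, with a 3.4-fold higher number from compound 2 to compound 4 (0.53 log units; beyond the scatter), whereas a 1.6-fold lower number from compound 1 to compound 4 (0.22 log units; within the scatter) leaves those two compounds unranked, so across these four compounds the two halogen-bearing rings give lower numbers than the two oxygen-bearing rings, and none goes against this. Nothing measured alongside these compounds accounts for the rise.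

Hydroxy carries a hydrogen-bond donor and acceptor that chloro lacks, but a single exchange cannot tell whether those features are linked to the higher number or whether any replacement of chloro would do the same. The compounds shown leave open what a methyl or an amine on the same aromatic carbon would give, and such groups could help separate the loss of the halogen from the arrival of the hydroxy.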